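The compounds below may be only part of what the source reports. "The series", "measured", "known", "first", "only" and "open" are said of these compounds alone.

Working notes on the series.

Two compounds of the series have a value in an ADME assay on the whole organism (Mus musculus, strain CD1) for metabolic stability, read by LC-MS, with a stated time of 24 h, at a dose of 1 mg/kg by the intravenous route; a lower number here means that the compound disappears faster, a higher number that the compound lasts longer. Compound 1 `O=C(O)Cn1nc(Cc2nc3cc(Cl)c(OCC(F)F)cc3[nH]2)c2ccccc2c1=O` gives 0.3 h in this assay. Compound 2 `CCC(C(=O)O)c1nn(Cc2cn3cc(OCC4CC4)c(Cl)cc3n2)c2ccccc2c1=O` gives 0.8 h in this assay, the higher of the two numbers; the gap to compound 1 lies beyond the scatter, so compound 2 stands as the longer-lasting of the pair. Within the data shown here, no pair differing in one place only has been measured, so no single step is known.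

Compound 3 `C[C@H](C(=O)O)c1nn(Cc2cn3cc(OCC4CC4)c(Cl)cc3n2)c2ccccc2c1=O` is the next compound to be measured in this assay. Against compound 2 it differs as follows: 1-carboxyethyl in place of 1-carboxypropyl on an aromatic carbon. The shared core and the remaining substituents are unchanged; only the acid-bearing side chain is shortened by one carbon, with one defined stereocentre entering.

With no measured step of this kind in the series, nothing in the data argues for a step beyond the scatter in either direction. The step expected in this assay is a 1.1-fold lower number from compound 2 to compound 3 (0.06 log units; within the scatter), essentially no change. Compound 3 is therefore estimated at 0.7 h in this assay, with a range from 0.35 h to 1.4 h.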

Compound 3, half-life: 0.8 h
Compound 3: middle estimate off by 1.1-fold (0.06 log units), on the low side, and the stated range covers the measured number.
By their numbers in this assay, from the lowest: compound 1; then compounds 2 and 3 (each within the scatter of the next).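

In this assay the series now has its first single-place step, and replacing 1-carboxypropyl with 1-carboxyethyl gives no change at the digits printed from compound 2 to compound 3 (within the scatter). At this place, on an aromatic carbon next to the ring nitrogen, the half-life therefore does not respond to this one-carbon difference in the acid-bearing chain, even though the entering group also carries one defined stereocentre. Nothing at hand bears on why the number holds.

This single step covers only two closely related chains that both keep the carboxylic acid, and the shorter chain and the defined stereocentre enter together, so their separate contributions cannot be told apart. The compounds shown leave open whether the half-life would hold with a longer chain than 1-carboxypropyl, with the opposite stereocentre in 1-carboxyethyl, or with an amide or an amine in place of the carboxylic acid at this place, and they give no single-place step for any other part of the shared core.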